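Microsomal clearance in the aryl urea series: compound 3

The source may hold more compounds than are shown below. What is called first, only, known or untested is meant among the compounds shown, and "the series" means these compounds.

compound 1 `COc1ccccc1C(=O)NC(=O)Nc1ccc(-c2ccccc2)c(C(F)(F)F)c1`: 15 mL.min-1.g-1
compound 2 `COc1ccccc1C(=O)NC(=O)Nc1ccc(-c2nccs2)c(C(F)(F)F)c1`: 33 mL.min-1.g-1

In an in vitro ADME assay on microsomes from liver (Rattus norvegicus) for metabolic stability, with a stated time of 30 min (a higher number here means faster removal of the compound, a lower number slower removal), compound 1 gives 15 mL.min-1.g-1 and compound 2 gives 33 mL.min-1.g-1. Among the compounds with values here, compound 2 thus stands highest of the two numbers, its only neighbour being compound 1, and the only measured step is a 2.2-fold higher number from compound 1 to compound 2 (0.34 log units; beyond the scatter). Compound 3 `COc1ccccc1C(=O)NC(=O)Nc1ccc(OCC(F)(F)F)c(C(F)(F)F)c1` carries the change (2,2,2-trifluoroethoxy in place of 1,3-thiazol-2-yl on an aromatic carbon). Within the data shown here, that step bears only loosely here, since no measured pair exchanges a ring for an open chain at this position. A modest move is expected, most likely back toward compound 1. Compound 3 is therefore estimated at 20 mL.min-1.g-1, within 8 mL.min-1.g-1 to 50 mL.min-1.g-1, an expected step of a 1.7-fold lower number from compound 2 to compound 3 (0.22 log units; within the scatter).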

Compound 3, intrinsic clearance in microsomes: 25 mL.min-1.g-1
Compound 3: middle estimate off by 1.3-fold (0.10 log units), on the low side; the measured number falls inside the stated range.
By their numbers in this assay, from the lowest: compounds 1, 3 and 2 (each within the scatter of the next, the first and the last beyond it).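

Working from this assay, this position accepts 2,2,2-trifluoroethoxy, a group with no ring, without leaving the scatter of either ring-bearing compound (a 1.3-fold lower number from compound 2 to compound 3 (0.12 log units; within the scatter)) (a 1.7-fold higher number from compound 1 to compound 3 (0.22 log units; within the scatter)). Compound 3 therefore does not extend the range set by the two aromatic rings, and a ring at this position is not needed for a number inside that range. Nothing available bears on the reason for these numbers.

Open, as far as these compounds go, is whether an amine or a carboxylic acid here would take the number beyond the scatter of compound 3. Also open, from the compounds shown here alone, is whether a longer fluorinated ether chain would stay within it.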